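The source may report more compounds than this note shows. Statements on the series, on what has been measured and on what is new or still open speak of the compounds shown alone.

Three compounds share one core and differ only in the amine attached to it. Compound 1 `COc1cc(/C=C/c2nc(N(C)C)c3sccc3n2)cc(OC)c1OC` carries a dimethylamino group. In a functional assay on L02 cells (Homo sapiens) for inhibition, read by Griess assay, with stated times of 1 h and 24 h (a higher number here means a weaker inhibitor, a lower number a stronger inhibitor), compound 1 gives only a limit, > 1000000 nM. Compound 2 `COc1cc(/C=C/c2nc(N3CCCC3)c3sccc3n2)cc(OC)c1OC` carries a pyrrolidin-1-yl group, and in this assay compound 2 gives 681000 nM. Compound 3 `CCN1CCN(c2nc(/C=C/c3cc(OC)c(OC)c(OC)c3)nc3ccsc23)CC1` carries a 4-ethylpiperazin-1-yl group. In this assay compound 3 again gives only a limit, > 1000000 nM. So compound 3 stands at the edge of what this assay can report, a position it shares with compound 1 (the limit of > 1000000 nM in this assay, at which 2 of the 3 values shown sit). The steps among these three are small: an at least 1.4-fold lower number from compound 1 to compound 2 (0.16 log units; that floor lies within the scatter), an at least 1.4-fold higher number from compound 2 to compound 3 (0.16 log units; that floor lies within the scatter), and a step that the two limits leave unreadable from compound 1 to compound 3. Compound 4 `COc1cc(/C=C/c2nc(Nc3ccc(C(C)C)cc3)c3sccc3n2)cc(OC)c1OC` is not yet measured. It differs from compound 3 in one place: (4-isopropylphenyl)amino in place of 4-ethylpiperazin-1-yl on an aromatic carbon. Every measured step swaps one small saturated amine for another; none replaces such an amine with an arylamino group, so none bears directly on this change, and the steps that do exist sit within the scatter. The expected step of an at least 1.6-fold lower number from compound 3 to compound 4 (0.22 log units; that floor lies within the scatter) is accordingly small and without a clear direction. Compound 4 is estimated at 600000 nM in this assay, within 150000 nM to 1000000 nM, with a real chance that only a limit is reported.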

Compound 4, half-maximal inhibitory concentration: 370000 nM
For compound 4 the middle estimate is 1.6-fold (0.21 log units) above the measured one, and the stated range covers the measured number.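

In this assay, (4-isopropylphenyl)amino is the first arylamino group on this aromatic carbon next to the ring nitrogen, and replacing a small saturated amine with it gives an at least 2.7-fold lower number from compound 3 to compound 4 (0.43 log units; beyond the scatter) and an at least 2.7-fold lower number from compound 1 to compound 4 (0.43 log units; beyond the scatter); none of the earlier steps among the saturated amines was shown to exceed the scatter. Compound 2 goes against any simple gain for the arylamino group, since the change from its pyrrolidin-1-yl group gives a 1.8-fold lower number from compound 2 to compound 4 (0.26 log units; within the scatter), so compound 2 and compound 4 cannot be ranked. The steps from compound 1 and compound 3 are floors rather than full sizes, because each of these two compounds gives only a limit: the limit of > 1000000 nM in this assay, at which 2 of the 4 values shown sit.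

With a single arylamino group among the compounds shown, they do not separate the contribution of the aromatic ring from that of the isopropyl group or of the hydrogen on the linking nitrogen; a plain phenylamino group or a 4-methoxyphenylamino group at the same place would help to tell these apart. How a morpholin-4-yl group would compare with the saturated amines shown also remains open.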